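The compounds below may be only part of what the source reports. "The series", "measured", "known", "first", "only" and "open" are said of these compounds alone.

Compound 1, `C=CCSc1nncc2cnc(-c3ccccc3)n12`, gives in a functional assay for inhibition, with Homo sapiens as the target (on this read-out higher numbers stand for weaker inhibition and lower numbers for stronger inhibition), the value > 48000 nM, which is a limit of the assay and not a number.
Compound 2, `Sc1nncc2cnc(-c3ccccc3)n12`, gives in this assay the value > 48000 nM, again a limit of the assay.

Compound 2 therefore stands at the limit of this assay, and nothing places it more precisely: both values shown sit at that same limit, as the limit of > 48000 nM in this assay, at which 2 of the 2 values shown sit, makes clear. Going by the values given here, the one measured step, a step that the two limits leave unreadable from compound 1 to compound 2, cannot be read in size, since each of its two ends is a limit rather than a number. Compound 3, `Sc1nncc2cnc(-c3cccc(Cl)c3)n12`, differs from compound 2 by chloro in place of hydrogen on an aromatic carbon. No measured step touches this part of the molecule, so the only guide is that every compound shown so far rests at the limit. Compound 3 is therefore expected to remain at about the same level, with the step of a number no higher from compound 2 to compound 3 (the limit leaves the size open) estimated as no change beyond the scatter. The estimate for compound 3 in this assay is 48000 nM, with a range from 20000 nM to 150000 nM, and it is expected that the measurement will most likely again report only a limit.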

Compound 3, half-maximal inhibitory concentration: > 48000 nM
Compound 3 gave a limit, no number; the forecaster's own chance of this, stated with the estimate: 85%; the middle value lies on the limit itself.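

The step from compound 2 to compound 3, chloro in place of hydrogen on an aromatic carbon, cannot be read in size, since both ends are limits in this assay and not numbers. The compounds shown leave open how strongly any of them inhibits and which change could yield a measurable value, as all rest at one point: the limit of > 48000 nM in this assay, at which 3 of the 3 values shown sit.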